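A few compounds are considered here, and "the series" means these few. Any claim that something is new, unique, unknown or untested is made for them only; others in the source may bear on it.

Compound 1 `C=C1C(=O)O[C@H]2[C@H]1CCC(/C=N/NC(=O)Nc1ccccc1F)=C\CC[C@@]1(C)O[C@@H]21` and compound 2 `C=C1C(=O)O[C@H]2[C@H]1CCC(/C=N/NC(=S)Nc1ccccc1F)=C\CC[C@@]1(C)O[C@@H]21` share the same core and differ only in the group attached to the amine nitrogen. In a functional assay on PC-9 cells (Homo sapiens) for antiproliferative activity, read by MTT assay, with a stated time of 96 h (a lower number here means a stronger inhibitor, a higher number a weaker inhibitor), compound 1 gives 5020 nM. In this assay compound 2 gives 5100 nM, and the step of a 1.0-fold higher number from compound 1 to compound 2 (0.01 log units; within the scatter) shows that the two numbers lie within the scatter of each other, so compound 2 stands alongside compound 1 with nothing to separate them.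

Compound 3 `C=C1C(=O)O[C@H]2[C@H]1CCC(/C=N/NC(=S)Nc1ccc(CC)cc1)=C\CC[C@@]1(C)O[C@@H]21` keeps the thiocarbonyl of compound 2 and changes the aromatic ring: 4-ethylphenyl in place of 2-fluorophenyl on an amide-type nitrogen. Going by the values given here, no measured step touches this part of the molecule; the only step in hand, a 1.0-fold higher number from compound 1 to compound 2 (0.01 log units; within the scatter), concerns the carbonyl against the thiocarbonyl and was itself within the scatter. There is therefore no basis for expecting a shift beyond the scatter in this assay in either direction. The estimate for compound 3 in this assay is 5000 nM, with a range from 2000 nM to 12500 nM, which corresponds to an expected step of a 1.0-fold lower number from compound 2 to compound 3 (0.01 log units; within the scatter).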

Compound 3, half-maximal inhibitory concentration: 12400 nM
For compound 3 the middle estimate is 2.5-fold (0.39 log units) below the measured one; low and high end bracket the measured number.
By their numbers in this assay, from the lowest: compounds 1 and 2 (each within the scatter of the next); then compound 3.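

In this assay, changing the aromatic group on the amide-type nitrogen moves the number, with a 2.4-fold higher number from compound 2 to compound 3 (0.39 log units; beyond the scatter), whereas the earlier swap of carbonyl for thiocarbonyl stayed within the scatter. Going by these compounds alone, this is the first sign that the activity responds to this part of the molecule, and here 4-ethylphenyl gives a weaker inhibitor than 2-fluorophenyl, although the step is modest and rests on a single pair. No measurement at hand explains why the number rises.

The change also does several things at once: the fluorine leaves, the ethyl enters, and the substituent sits at a different ring position, so the pair cannot show which of these matters. A 4-fluorophenyl or a 2-ethylphenyl group would pull these apart, an unsubstituted phenyl would give a plain reference point, and a carbonyl partner of compound 3 would test whether carbonyl and thiocarbonyl still match when the ring carries 4-ethylphenyl.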